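The compounds below may be only part of what the source reports. "The series", "measured", "known", "first", "only" and "open" are said of these compounds alone.

Of the compounds shown here, three have been measured in a functional assay on A2780 cells (Homo sapiens) for inhibition, read by sulforhodamine B assay, with a stated time of 72 h; a lower number here means a stronger inhibitor, a higher number a weaker inhibitor. Compound 1 `O=C(NCc1ccc(S(=O)(=O)c2ccccc2)cc1)c1cc2ncccc2s1` reaches only the limit of the measurement and gives > 10000 nM. Compound 3 `Cn1c(C(=O)NCc2ccc(S(=O)(=O)c3ccccc3)cc2)cc2ccncc21` likewise stops at the limit, with > 10000 nM. Among the measured compounds shown here, compound 2 `Cc1cccc(S(=O)(=O)c2ccc(CNC(=O)c3cc4cnccc4[nH]3)cc2)c1` is the one compound with a number: in this assay compound 2 gives 4 nM, the single value that is not a limit, while the other two sit at the limit of > 10000 nM in this assay, at which 2 of the 3 values shown sit. Compound 2 therefore stands alone among the numbers shown, and nothing measured so far frames it on either side.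

The step to compound 4 `O=C(NCc1ccc(S(=O)(=O)c2ccccc2C(F)(F)F)cc1)c1cc2cnccc2[nH]1` changes one group: 2-(trifluoromethyl)phenyl in place of 3-methylphenyl on a sulfonyl sulfur. For the measured compounds named here, no measured pair differs in a single place, so the size of this step has no precedent among the values shown, and the two limits give no guide to it either. A modest weakening beyond the usual scatter is expected, the estimated step from compound 2 being a 7.5-fold higher number from compound 2 to compound 4 (0.88 log units; beyond the scatter). Compound 4 is thus expected to come in at 30 nM, with a range from 5 nM to 300 nM.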

Compound 4, half-maximal inhibitory concentration: 25 nM
For compound 4 the middle estimate is 1.2-fold (0.08 log units) above the measured one; low and high end bracket the measured number.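

Among the compounds shown here, the step at the sulfonyl sulfur is the first single change that can be read in this assay, and it runs as a 6.3-fold higher number from compound 2 to compound 4 (0.80 log units; beyond the scatter). The position therefore responds to a change of its aromatic group, yet with 2-(trifluoromethyl)phenyl, which has 10 heavy atoms in place of 7, compound 4 still gives a measured number of 25 nM rather than a limit. Nothing measured here accounts for the size of this step.

The change replaces the methyl group with trifluoromethyl and also moves the substituent around the ring, and this single pair cannot separate those two differences. Going by these compounds, how the position would respond to an unsubstituted phenyl ring, or to an aromatic ring carrying an amine or a carboxylic acid, also remains open.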